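The compounds below may be only part of what the source reports. "The series", "measured", "known", "first", "only" and "open" are said of these compounds alone.

In an assay on HEK293 cells for agonist activity at Toll-like receptor 8 (Homo sapiens), read by spectrophotometry (on this read-out higher numbers stand for an effect only at larger amounts of compound and lower numbers for an effect already at smaller amounts), three close relatives of a shared core have been measured. Compound 1 `CCCCNc1nc(N)nc(C)c1CCCCc1ccccc1` gives 857 nM. Compound 2 `CCCCNc1nc(N)nc(C)c1CCCN1CCCCC1` gives 133 nM, the lowest number of the three; compound 3 `CCCCNc1nc(N)nc(C)c1CC` gives 1660 nM. Going from compound 1 to compound 2 there was a 6.4-fold lower number from compound 1 to compound 2 (0.81 log units; beyond the scatter), and going from compound 2 to compound 3 there was a 12-fold higher number from compound 2 to compound 3 (1.10 log units; beyond the scatter), so the group carried three bonds out on the chain matters, and the piperidin-1-yl ring has done best so far.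

Compound 4 `CCCCNc1nc(N)nc(C)c1CCCn1cccn1` has not yet been measured. It differs from compound 2 in one place: 1H-pyrazol-1-yl in place of piperidin-1-yl on a saturated chain carbon, three bonds along the chain from an aromatic carbon. Both measured steps bear on this change. The 1H-pyrazol-1-yl ring is aromatic, as the benzyl of compound 1 was, which pointed toward higher numbers, yet unlike compound 3 the chain still ends in a ring. A modest rise in the number is therefore expected, landing between compound 2 and compound 1, with a 3.0-fold higher number from compound 2 to compound 4 (0.48 log units; beyond the scatter) as the expected step. Compound 4 is estimated to give 400 nM in this assay, with a plausible range from 150 nM to 1200 nM.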

Compound 4, half-maximal effective concentration: 1050 nM
Estimate against measurement, compound 4: 2.6-fold (0.42 log units) below, within the range that was stated.
By their numbers in this assay, from the lowest: compound 2; then compounds 1, 4 and 3 (each within the scatter of the next).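

In this assay, placing 1H-pyrazol-1-yl rather than piperidin-1-yl on a saturated chain carbon, three bonds along the chain from an aromatic carbon, gives a 7.9-fold higher number from compound 2 to compound 4 (0.90 log units; beyond the scatter), so the low number of compound 2 does not follow from simply having any ring at the end of the chain. Going by these compounds alone, the pyrazole-bearing compound 4 also does not separate from the other two compounds, with a 1.6-fold lower number from compound 3 to compound 4 (0.20 log units; within the scatter) and a 1.2-fold higher number from compound 1 to compound 4 (0.09 log units; within the scatter), both within the scatter, which leaves piperidin-1-yl as the only one of these end groups that stands apart from the rest. No measurement available here explains why the six-membered non-aromatic ring behaves differently from the five-membered aromatic ring.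

The compounds shown leave open whether the ring nitrogen of piperidin-1-yl matters, or whether the non-aromatic ring alone is enough, a question that cyclohexyl in the same place would address. They also leave open how much of the ring is needed, which pyrrolidin-1-yl, morpholin-4-yl or an open-chain diethylamino group at this position could begin to show.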